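This account rests on a few compounds, and the source may have more. Where it says the series, first, only, none or still open, it means among the compounds named here.

Working notes on the series.

Compound 1 `COc1ccc([N+](=O)[O-])cc1CSc1nc2cc(NC(=O)NC(C)(C)C)ccc2n1Cc1cccnc1` and compound 2 `COc1ccc([N+](=O)[O-])cc1CSc1nc2cc(NC(=O)NC(C)(C)C)ccc2n1Cc1ccncc1` share one core, and compound 3 `CCCn1c(SCc2cc([N+](=O)[O-])ccc2OC)nc2cc(NC(=O)NC(C)(C)C)cc(C(=O)NCc3ccncc3)c21` carries a different core. In an assay on isolated protein for inhibition of Gonadotropin-releasing hormone receptor (Rattus norvegicus) (on this read-out higher numbers stand for weaker inhibition and lower numbers for stronger inhibition), compound 1 gives 150 nM, compound 2 gives 240 nM and compound 3 gives 35 nM. The difference between the two cores is not broken down here; compound 3 simply stands with the lowest of the three numbers, its nearest neighbour being compound 1 and its furthest compound 2, both of them beyond the scatter.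

Within the core of compound 1 the only change from compound 2 is pyridin-3-yl in place of pyridin-4-yl on a saturated chain carbon bound to an aromatic nitrogen, and the step in this assay is a 1.6-fold lower number from compound 2 to compound 1 (0.20 log units; within the scatter).

Compound 4 `CCCn1c(SCc2cc([N+](=O)[O-])ccc2OC)nc2cc(NC(=O)NC(C)(C)C)cc(C(=O)NCc3cccnc3)c21` has not yet been measured. It differs from compound 3 by pyridin-3-yl in place of pyridin-4-yl on a saturated chain carbon bound to an amide-type nitrogen. Among the compounds with values here, this is the same kind of change as the one from compound 2 to compound 1, but the surroundings differ: in the measured pair the saturated chain carbon is bound to an aromatic nitrogen, whereas in compound 4 it is bound to an amide-type nitrogen. The step from compound 3 to compound 4 in this assay is expected to be a 1.3-fold lower number from compound 3 to compound 4 (0.10 log units; within the scatter), a small one, because the measured step of a 1.6-fold lower number from compound 2 to compound 1 (0.20 log units; within the scatter) in the earlier pair lies within the scatter. Given that, compound 4 is estimated at 28 nM, with a plausible range from 12 nM to 70 nM.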

Compound 4, half-maximal inhibitory concentration: 54 nM
Beside the measured number, compound 4's estimate is 1.9-fold (0.29 log units) below it, within the range that was stated.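

In this assay, pyridin-3-yl in place of pyridin-4-yl on a saturated chain carbon bound to an amide-type nitrogen gives a 1.5-fold higher number from compound 3 to compound 4 (0.19 log units; within the scatter). Set beside the same change on the core of compound 1, the two steps do not differ beyond what repeated measurement would produce: the same change on two cores in this assay, a 1.6-fold lower number (0.20 log units; within the scatter) from compound 2 to compound 1 and a 1.5-fold higher number (0.19 log units; within the scatter) from compound 3 to compound 4, 2.5-fold (0.39 log units) apart, within the scatter of two such steps. On these two pairs the change between pyridin-4-yl and pyridin-3-yl carries over from one core to the other as a step within the scatter in both surroundings, and the opposite signs of the two steps carry no weight; this does not show that the change would stay this small on a further core, nor that the two cores respond identically, since two pairs of this size can only fail to separate.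

The compounds shown leave open what a group other than these two pyridinyl rings would do at this place, such as pyridin-2-yl, a plain phenyl, or a ring bearing an amine or a carboxylic acid. Within the data shown here, they also leave open how much of the gap between the two cores belongs to the propyl chain on the aromatic nitrogen and how much to the ((pyridin-4-yl)methyl)carbamoyl group, as no pair here separates the two.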